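Pyridine attachment point on the shared core: compound 4

The source may hold more compounds than are shown below. What is called first, only, known or untested is meant among the compounds shown, and "the series" means these compounds.

Compound 1 `Cc1cn2c(/C=N/NC(=N)N)c(-c3cccnc3)nc2s1` gives 10200 nM in a functional assay (Homo sapiens) for antiproliferative activity (a higher number here means a weaker inhibitor of growth, a lower number a stronger inhibitor of growth), the lowest of the three numbers, though compound 2 `N=C(N)N/N=C/c1c(-c2cc([N+](=O)[O-])c(Cl)cc2Cl)nc2sc(Cl)cn12` with 11200 nM and compound 3 `N=C(N)N/N=C/c1c(-c2cccnc2)nc2sc(Cl)cn12` with 18200 nM both lie within the scatter of it. Going by the values given here, the only one-place step known, a 1.8-fold higher number from compound 1 to compound 3 (0.25 log units; within the scatter), is within the scatter. Compound 4 `Cc1cn2c(/C=N/NC(=N)N)c(-c3ccccn3)nc2s1` differs from compound 1 by pyridin-2-yl in place of pyridin-3-yl on an aromatic carbon. Among the compounds with values here, no measured step touches the pyridine attachment; compound 2 and compound 3, which differ in the aryl group, show values within the scatter of each other. The step from compound 1 to compound 4 is therefore expected to be a 1.1-fold higher number from compound 1 to compound 4 (0.03 log units; within the scatter), with no change beyond the scatter. Compound 4 is estimated at 11000 nM, range 4000 nM to 30000 nM.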

Compound 4, concentration for 50% growth inhibition: 9770 nM
Compound 4: middle estimate off by 1.1-fold (0.05 log units), on the high side; the measured number falls inside the stated range.
By their numbers in this assay, from the lowest: compounds 4, 1, 2 and 3 (each within the scatter of the next).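

In this assay, going by these compounds alone, pyridin-2-yl in place of pyridin-3-yl on this aromatic carbon gives a 1.0-fold lower number from compound 1 to compound 4 (0.02 log units; within the scatter), the only direct reading of the pyridine attachment point on the shared core. At this carbon, with the methyl-bearing core, the assay does not separate these two pyridine attachments. No measurement available here explains this result.

On these data alone, whether pyridin-4-yl or unsubstituted phenyl at the same carbon would read alike remains open. Also open, as far as these compounds go, is whether pyridin-2-yl behaves the same with chloro in place of methyl on the core.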